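This account rests on a few compounds, and the source may have more. Where it says the series, first, only, none or still open, it means among the compounds named here.

Working notes on the series.

Compound 1 `COc1ccc(-c2nc3cc(/C(C)=N/O)ccc3[nH]2)c(OC)c1` is the starting point. In an ADME assay on BHK-21 cells (Mesocricetus auratus) for cytotoxicity, read by MTT assay (on this read-out lower numbers stand for higher toxicity in this test and higher numbers for lower toxicity in this test), compound 1 gives > 100000 nM, which is a limit of the assay and not a number. Compound 2 `COc1ccc(-c2nc3cc(/C(C)=N/O)ccc3[nH]2)c(OC)c1OC` differs from compound 1 by methoxy in place of hydrogen on an aromatic carbon. In this assay compound 2 gives > 100000 nM, again a limit rather than a number. The step that the two limits leave unreadable from compound 1 to compound 2 is therefore of unreadable size. Compound 3 `COc1ccc(-c2nc3cc(/C(C)=N/NC(N)=S)ccc3n2C2CCCCC2)cc1` carries a different core; the difference between the two cores is not broken down here. For compound 3 in this assay there is no result: "not determined" (no result reported). Compound 4 `COc1ccc(-c2nc3cc(/C(C)=N/NC(N)=S)ccc3n2C2CCCCC2)c(OC)c1` is not yet measured; it differs from compound 3 by methoxy in place of hydrogen on an aromatic carbon. This is the same kind of change as from compound 1 to compound 2, but the surroundings differ: there the entering methoxy sat ortho to two methoxy groups and meta to a large group, here it sits ortho to a large group and meta to a methoxy group. The expectation for compound 4 rests on compound 1 and compound 2 both sitting at the limit of > 100000 nM in this assay, at which 2 of the 3 values shown sit. For compound 4 in this assay the value is expected to be 100000 nM, and it is estimated to lie between 30000 nM and 300000 nM.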

Compound 4, half-maximal cytotoxic concentration: 17000 nM
Compound 4: middle estimate off by 5.9-fold (0.77 log units), on the high side, and the stated range ends above it.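

Compound 3 has no numeric result in this assay, and compound 4 is its only partner differing in one place, so no new step can be read from this pair. The compounds shown leave open what the change from 4-methoxyphenyl to 2,4-dimethoxyphenyl does to the read-out in this assay on the core of compound 3.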